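A few compounds are considered here, and "the series" means these few. Any claim that something is new, unique, unknown or untested is made for them only; others in the source may bear on it.

In an ADME assay on microsomes from liver (Homo sapiens) for metabolic stability, read by LC-MS, using NADPH, with a stated time of 10 min, tested at 0.1 uM (on this read-out lower numbers stand for slow clearance and higher numbers for fast clearance), three compounds with a shared core have been measured. Compound 1 (`O=C(NCCCCc1ccccc1)c1cccc(C2SCC(=O)N2c2cccc(-c3c[nH]nn3)c2)c1`) gives 261 mL.min-1.g-1, compound 2 (`O=C(NCCCCc1ccccc1)c1cccc(C2SCC(=O)N2c2ccccn2)c1`) gives 412 mL.min-1.g-1 and compound 3 (`C#Cc1cccc(N2C(=O)CSC2c2cccc(C(=O)NCCCCc3ccccc3)c2)c1`) gives 751 mL.min-1.g-1. Compound 3 therefore sits at the fast-clearance end of this small set. Its gap to compound 2 stays within the scatter, at a 1.8-fold higher number from compound 2 to compound 3 (0.26 log units; within the scatter), while its gap to compound 1 does not, at a 2.9-fold higher number from compound 1 to compound 3 (0.46 log units; beyond the scatter).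

Compound 4 (`CC(F)(F)c1cccc(N2C(=O)CSC2c2cccc(C(=O)NCCCCc3ccccc3)c2)c1`) has 1,1-difluoroethyl in place of ethynyl on an aromatic carbon. The closest evidence is the modest step already given for compound 1, which involves ethynyl at this same place. The exchange of the whole group on the amide-type nitrogen in a ring, a 1.6-fold higher number from compound 1 to compound 2 (0.20 log units; within the scatter), stays within the scatter. Among the compounds with values here, no measured compound carries 1,1-difluoroethyl, so the data give no firm direction, and no change beyond the scatter is expected. The expected size of the change is a 1.2-fold lower number from compound 3 to compound 4 (0.06 log units; within the scatter). For compound 4 the estimated value is 650 mL.min-1.g-1, with an expected range from 300 mL.min-1.g-1 to 1400 mL.min-1.g-1.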

Compound 4, intrinsic clearance in microsomes: 1750 mL.min-1.g-1
Compound 4: middle estimate off by 2.7-fold (0.43 log units), on the low side; the whole stated range lies below it.
By their numbers in this assay, from the lowest: compounds 1, 2 and 3 (each within the scatter of the next, the first and the last beyond it); then compound 4.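

At this place, on an aromatic carbon meta to a large group, 1,1-difluoroethyl is the first exchange for ethynyl shown, and it raises intrinsic clearance further in this assay (a 2.3-fold higher number from compound 3 to compound 4 (0.37 log units; beyond the scatter)), so ethynyl no longer marks the fast-clearance end of the set. Compound 4 also stands clear of the two earlier compounds (a 4.2-fold higher number from compound 2 to compound 4 (0.63 log units; beyond the scatter); a 6.7-fold higher number from compound 1 to compound 4 (0.83 log units; beyond the scatter)), and the exchange of 1H-1,2,3-triazol-4-yl for 1,1-difluoroethyl gives the largest step among these compounds. Nothing measured here accounts for this rise.

As far as these compounds go, whether an amine or a carboxylic acid at this place would sit nearer compound 1 or compound 4 remains open. From the compounds shown here alone, how a plain ethyl group would compare with 1,1-difluoroethyl also remains open.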